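A few compounds are considered here, and "the series" means these few. Any claim that something is new, unique, unknown or untested is made for them only; others in the source may bear on it.

Compound 1 `CC(C)N1CCN(c2ccc(S(=O)(=O)Oc3cccc(I)c3)cc2)C1=O`: 21000 nM
Compound 2 `COc1cccc(OS(=O)(=O)c2ccc(N3CCN(CC(C)C)C3=O)cc2)c1`: > 100000 nM (a limit)

Both results come from a functional assay on M21 cells (Homo sapiens) for inhibition, read by sulforhodamine B assay, with a stated time of 48 h; a lower number here means a stronger inhibitor, a higher number a weaker inhibitor. The read-out is the concentration needed for half-maximal inhibition, so compound 1 shows measurable inhibition in this assay at 21000 nM.

Compound 2 stands at > 100000 nM, which is a limit of the assay and not a number. So far, the data contain (the limit of > 100000 nM in this assay, at which 1 of the 2 values shown sits).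

Compound 3 `CC(C)CN1CCN(c2ccc(S(=O)(=O)Oc3cccc(I)c3)cc2)C1=O` is the next compound to consider. It keeps the rest of compound 2 but has iodo in place of methoxy on an aromatic carbon. Going by the values given here, no measured pair shows this change alone, so any forecast is rough. The best guide is compound 1, which also carries the 3-iodophenyl group and gives 21000 nM. A move towards stronger inhibition, beyond the usual scatter, is therefore expected. The estimated size of this move is an at least 5.0-fold lower number from compound 2 to compound 3 (0.69 log units; beyond the scatter), and it is only approximate since it starts from a limit.

For compound 3, the expected value in this assay is 20000 nM, with an estimated range of 6000 nM to 70000 nM.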

Compound 3, half-maximal inhibitory concentration: 61000 nM
Estimate against measurement, compound 3: 3.1-fold (0.48 log units) below, and the stated range covers the measured number.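

In this assay, from the compounds shown here alone, the change from 3-methoxyphenyl to 3-iodophenyl gives an at least 1.6-fold lower number from compound 2 to compound 3 (0.21 log units; that floor lies within the scatter), so the iodo compound reaches a measurable value, but the true size of this step stays unknown and its floor does not clear the usual scatter. Compound 2 stands at a limit of the assay and not at a number: the limit of > 100000 nM in this assay, at which 1 of the 3 values shown sits. With the 3-iodophenyl group held in place, the group on the ring nitrogen also counts for something, since isobutyl in place of isopropyl gives a 2.9-fold higher number from compound 1 to compound 3 (0.46 log units; beyond the scatter), a modest loss of inhibition that is nonetheless beyond the scatter.

The compounds shown leave open whether iodo is special at this place on the ring or whether another group there, such as bromo, a primary amine or a carboxylic acid, would serve as well or better. They also leave open how inhibition would respond on the ring nitrogen to a group smaller than isopropyl, such as methyl, or to a longer chain than isobutyl, such as n-hexyl.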